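Swapping bromo for cyano on the aryl ring

The source may hold more compounds than are shown below. What is called first, only, known or untested is meant among the compounds shown, and "the series" means these compounds.

Measured in a functional assay on HT-29 cells (Homo sapiens) for cytotoxicity, read by MTT assay, with a stated time of 48 h; a higher number here means a weaker inhibitor, a lower number a stronger inhibitor:
Compound 1 `OC[C@@H]1C[C@H](CO)[C@@H]2C(c3ccc(Cl)cc3)=NO[C@H]12`: 22.9 ug/mL
Compound 2 `Cc1ccc(C2=NO[C@@H]3[C@H](CO)C[C@H](CO)[C@H]23)cc1`: > 50 ug/mL, a limit
Compound 3 `OC[C@@H]1C[C@H](CO)[C@@H]2C(c3ccc(Br)cc3)=NO[C@H]12`: 37.3 ug/mL

Compound 3, at 37.3 ug/mL, stands within the scatter of its nearest neighbour, with a 1.6-fold higher number from compound 1 to compound 3 (0.21 log units; within the scatter). Compound 4 `N#Cc1ccc(C2=NO[C@@H]3[C@H](CO)C[C@H](CO)[C@H]23)cc1` carries cyano in place of bromo on an aromatic carbon, para to a large group (cyano in place of bromo on an aromatic carbon). Two measured steps at this same place bear on it: a 1.6-fold higher number from compound 1 to compound 3 (0.21 log units; within the scatter), and an at least 2.1-fold higher number from compound 1 to compound 2 (0.33 log units; beyond the scatter). The second of these rests on a limit. Neither involves cyano, so no step beyond the scatter is expected in this assay. The expected step is a 1.1-fold lower number from compound 3 to compound 4 (0.03 log units; within the scatter). For compound 4 the estimated value is 35 ug/mL, with an expected range from 17 ug/mL to 60 ug/mL.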

Compound 4, half-maximal inhibitory concentration: > 50 ug/mL
Compound 4: no number, only a limit; the forecaster's own chance of this, stated with the estimate: 30%; middle value at least 1.4-fold (0.15 log units) away from the limit.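

In this assay compound 4 gives only a limit, shared with compound 2: the limit of > 50 ug/mL in this assay, at which 2 of the 4 values shown sit.

On the aryl ring, cyano separates from chloro, with an at least 2.1-fold higher number from compound 1 to compound 4 (0.33 log units; beyond the scatter), but not from bromo, where an at least 1.3-fold higher number from compound 3 to compound 4 (0.12 log units; that floor lies within the scatter) leaves only a floor inside the scatter. The step between compound 2 and compound 4 cannot be read, so methyl and cyano cannot be ordered.

From the compounds shown here alone, how far either compound lies past the limit stays open. So does whether an amine or a carboxylic acid at this position, para to a large group, would give a lower number.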